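Swapping an open-chain diol side group for a five-membered ring

This account rests on a few compounds, and the source may have more. Where it says the series, first, only, none or still open, it means among the compounds named here.

Measured in a functional assay on BV-2 cells (Mus musculus) for inhibition, read by Griess assay, with a stated time of 24 h; a lower number here means a stronger inhibitor, a higher number a weaker inhibitor:
Compound 1 `C=C1CC[C@@H]2[C@](C)(CC[C@H](O)[C@]2(C)C(=O)O[C@@H]2O[C@H](CO)[C@@H](O)[C@H](O)[C@H]2O)[C@H]1CCC1=CCOC1=O` gives 68800 nM.
Compound 2 `C=C1CC[C@@H]2[C@](C)(CCC[C@]2(C)C(=O)O[C@@H]2O[C@@H](CO)[C@H](O)[C@H]2O)[C@H]1CCC1=CCOC1=O` gives only a limit, > 500000 nM.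
Compound 3 `C=C1CC[C@@H]2[C@](C)(CCC[C@]2(C)C(=O)O[C@@H]2O[C@H](CO)[C@@H](O)[C@H](O)[C@H]2O)[C@H]1CC/C(=C\CO)CO` gives 65400 nM.

Of the two numbers shown, compound 3 has the lower one, but compound 1 sits within the usual scatter of it, so no order between the two can be read. The value of compound 2 is a limit of the assay, (the limit of > 500000 nM in this assay, at which 1 of the 3 values shown sits), and not a number.

Compound 4 `C=C1CC[C@@H]2[C@](C)(CCC[C@]2(C)C(=O)O[C@@H]2O[C@H](CO)[C@@H](O)[C@H](O)[C@H]2O)[C@H]1CCC1=CCOC1=O` has not been measured. It differs from compound 3 in one place: a group of 6 heavy atoms (4 carbon, 2 oxygen; one five-membered non-aromatic ring with 1 hetero atom) in place of a group of 6 heavy atoms (4 carbon, 2 oxygen; no ring), on a saturated chain carbon, two bonds along the chain from a saturated ring carbon. Among the compounds with values here, with no comparable step between measured compounds to draw on, the step is expected to be small, a 1.1-fold higher number from compound 3 to compound 4 (0.03 log units; within the scatter), in no settled direction. Compound 4 is therefore estimated at 70000 nM in this assay, between 25000 nM and 200000 nM.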

Compound 4, half-maximal inhibitory concentration: 65800 nM
For compound 4 the middle estimate is 1.1-fold (0.03 log units) above the measured one; measured number inside the range.
By their numbers in this assay, from the lowest: compounds 3, 4 and 1 (each within the scatter of the next). At a limit, above all of these: compound 2.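

At this place on the chain, this assay does not separate the five-membered ring from the open-chain group (a 1.0-fold higher number from compound 3 to compound 4 (0.00 log units; within the scatter)), and the same holds for hydrogen in place of hydroxy on a saturated ring carbon (a 1.0-fold lower number from compound 1 to compound 4 (0.02 log units; within the scatter)). The sugar on the oxygen next to a carbonyl group does matter, with 3,4,5-trihydroxy-6-(hydroxymethyl)oxan-2-yl in place of 3,4-dihydroxy-5-(hydroxymethyl)oxolan-2-yl (an at least 7.5-fold lower number from compound 2 to compound 4 (0.88 log units; beyond the scatter)). The value of compound 2 is a limit, not a number: the limit of > 500000 nM in this assay, at which 1 of the 4 values shown sits.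

The compounds shown leave open whether an amine, a carboxylic acid or a longer chain at this place would give a step beyond the scatter.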